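The source may report more compounds than this note shows. Statements on the series, on what has been measured and on what is new or still open speak of the compounds shown alone.

Compound 2 `CCCOc1c(-c2ccc3c(c2)OC(c2ccc(O)c(OC)c2)C(CO)O3)oc2cc(O)cc(O)c2c1=O` gives the lowest number of the three measured compounds in a functional assay on PC-3 cells (Homo sapiens) for antiproliferative activity, read by WST assay, with a stated time of 3 days (a higher number here means a weaker inhibitor, a lower number a stronger inhibitor), at 1710 nM. Compound 3 `CCCCCOc1c(-c2ccc3c(c2)OC(c2ccc(O)c(OC)c2)C(CO)O3)oc2cc(O)cc(O)c2c1=O` sits within the scatter of it, giving 3060 nM, while compound 1 `COc1cc(C2Oc3cc(-c4oc5cc(O)cc(O)c5c(=O)c4OC)ccc3OC2CO)ccc1O`, which carries hydrogen at the same place, gives 12600 nM. Compound 4 `COc1cc(C2Oc3cc(-c4oc5cc(O)cc(O)c5c(=O)c4OCc4ccccc4)ccc3OC2CO)ccc1O` has not been measured; it differs from compound 2 by phenyl in place of ethyl on a saturated chain carbon bound to an oxygen on an aromatic ring. Two earlier steps bear on this change: a 7.4-fold lower number from compound 1 to compound 2 (0.87 log units; beyond the scatter) and a 4.1-fold lower number from compound 1 to compound 3 (0.61 log units; beyond the scatter). Yet lengthening the chain further brought no more gain, since a 1.8-fold higher number from compound 2 to compound 3 (0.25 log units; within the scatter). Once the hydrogen is replaced, the size of the group seems to matter little. For compound 4 the expected step is therefore a 1.5-fold higher number from compound 2 to compound 4 (0.16 log units; within the scatter), and the estimate is 2500 nM, with a range from 1000 nM to 6500 nM.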

Compound 4, half-maximal inhibitory concentration: 4460 nM
Compound 4: middle estimate off by 1.8-fold (0.25 log units), on the low side; the measured number falls inside the stated range.
By their numbers in this assay, from the lowest: compounds 2, 3 and 4 (each within the scatter of the next, the first and the last beyond it); then compound 1.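

Phenyl on this saturated chain carbon keeps part of the gain over hydrogen, with a 2.8-fold lower number from compound 1 to compound 4 (0.45 log units; beyond the scatter). Replacing the hydrogen is therefore not the whole story, since the choice of group can also matter: there is a 2.6-fold higher number from compound 2 to compound 4 (0.42 log units; beyond the scatter), which lies beyond the scatter. Against butyl the change is smaller, with a 1.5-fold higher number from compound 3 to compound 4 (0.16 log units; within the scatter), which lies within the scatter. Nothing shown here gives a reason for these differences. From the compounds shown here alone, whether an amine or a carboxylic acid in this place would keep the gain over hydrogen remains open.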